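Compound 4: Shifting the Side-Chain Oxygen Substituent

The compounds below may be only part of what the source reports. "The series", "measured", "known", "first", "only" and "open" are said of these compounds alone.

Three compounds share one core and were measured in a functional assay on DU-145 cells (Homo sapiens) for cytotoxicity, read by MTT assay; a higher number here means a weaker inhibitor, a lower number a stronger inhibitor:

- compound 1, `CCC(C)(O)CC(=O)O[C@H](CC=C(C)C)C1=CC(=O)c2c(O)ccc(O)c2C1=O`, gives 16000 nM
- compound 2, `CC(C)=CC[C@@H](OC(=O)CCO)C1=CC(=O)c2c(O)ccc(O)c2C1=O`, gives 55300 nM
- compound 3, `CC(C)=CC[C@@H](OC(=O)C1CCCOC1)C1=CC(=O)c2c(O)ccc(O)c2C1=O`, gives 29700 nM

Compound 3 stands second highest of these three numbers, yet its gaps to both neighbours are within the scatter: a 1.9-fold lower number from compound 2 to compound 3 (0.27 log units; within the scatter) and a 1.9-fold higher number from compound 1 to compound 3 (0.27 log units; within the scatter). Within the data shown here, the only step beyond the scatter is a 3.5-fold higher number from compound 1 to compound 2 (0.54 log units; beyond the scatter), and it too concerns the group attached to the carbonyl carbon.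

Compound 4, `CC(=O)OC(C)CO[C@H](CC=C(C)C)C1=CC(=O)c2c(O)ccc(O)c2C1=O`, differs from compound 3 in this way: 2-acetoxypropyl in place of (oxan-3-yl)carbonyl on an oxygen on a saturated carbon. Among the measured compounds shown here, none of the measured steps touch the oxygen on the saturated carbon itself; all three vary only what sits on the carbonyl carbon, and they span a modest range. For the measured compounds named here, the change in compound 4 is therefore of a different kind, and no measured step speaks to it directly. The cautious expectation is a step within the scatter, with wide uncertainty: a 1.0-fold higher number from compound 3 to compound 4 (0.00 log units; within the scatter) is the estimated step. Compound 4 is expected to give about 30000 nM, plausibly between 10000 nM and 90000 nM.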

Compound 4, half-maximal inhibitory concentration: 16600 nM
Estimate against measurement, compound 4: 1.8-fold (0.26 log units) above, and the stated range covers the measured number.
By their numbers in this assay, from the lowest: compounds 1, 4, 3 and 2 (each within the scatter of the next, the first and the last beyond it).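

Among these compounds, compound 4 is the first compound here whose group on this oxygen on a saturated carbon is not joined through a carbonyl, and the swap of (oxan-3-yl)carbonyl for open-chain 2-acetoxypropyl gives little change in this assay (a 1.8-fold lower number from compound 3 to compound 4 (0.25 log units; within the scatter)). Against the (2-hydroxy-2-methylbutyl)carbonyl group, the result is the same picture (a 1.0-fold higher number from compound 1 to compound 4 (0.02 log units; within the scatter)). So, among these compounds, neither that carbonyl nor the ring is needed to stay in this range, and only the (2-hydroxyethyl)carbonyl group stands apart (a 3.3-fold lower number from compound 2 to compound 4 (0.52 log units; beyond the scatter)).

Nothing available explains these numbers. On these data alone, whether an amine, a carboxylic acid or a longer chain on this oxygen would stay in the same range remains open.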